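A few compounds are considered here, and "the series" means these few. Any claim that something is new, unique, unknown or untested is made for them only; others in the source may bear on it.

Measured in a functional assay on MDA-MB-231 cells (Homo sapiens) for antiproliferative activity, read by MTT assay, with a stated time of 48 h; a higher number here means a weaker inhibitor of growth, a lower number a stronger inhibitor of growth:
Compound 1 `COC(=O)N1N=C(c2cccc(OC)c2)CC1c1cc(OC)c(OC)c(OC)c1`: 350 nM
Compound 2 `CCCOC(=O)N1N=C(c2cccc(OC)c2)CC1c1cc(OC)c(OC)c(OC)c1`: 12500 nM
Compound 3 `COc1cccc(C2=NN(C(=O)OCc3ccccc3)C(c3cc(OC)c(OC)c(OC)c3)C2)c1`: > 10000 nM

The reading for compound 3 is a limit and not a number. Of the two true numbers, compound 1 has the lower, at 350 nM, and compound 2 is its nearest neighbour. The next compound, compound 4 `CCOc1cccc(C2=NN(C(=O)OC)C(c3cc(OC)c(OC)c(OC)c3)C2)c1`, departs from compound 1 by one change: methyl in place of hydrogen on a saturated chain carbon bound to an oxygen on an aromatic ring. In words, methyl takes the place of hydrogen on a saturated chain carbon bound to an oxygen on an aromatic ring, so that methoxy becomes ethoxy and 3-methoxyphenyl becomes 3-ethoxyphenyl.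

For the measured compounds named here, no measured step touches this place. The closest guides are two enlargements on a saturated chain carbon bound to an oxygen next to a carbonyl group. They gave a 36-fold higher number from compound 1 to compound 2 (1.55 log units; beyond the scatter) and an at least 28-fold higher number from compound 1 to compound 3 (1.45 log units; beyond the scatter), both large and both towards weaker growth inhibition. They come from a different place in the molecule, so they suggest the direction more firmly than the size. A smaller move towards a higher number is therefore expected in this assay. The expected change is a 2.9-fold higher number from compound 1 to compound 4 (0.46 log units; beyond the scatter). For compound 4 the estimated value is 1000 nM, with an expected range from 300 nM to 4500 nM.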

Compound 4, concentration for 50% growth inhibition: 190 nM
Beside the measured number, compound 4's estimate is 5.3-fold (0.72 log units) above it, and the stated range ends above it.
By their numbers in this assay, from the lowest: compounds 4 and 1 (each within the scatter of the next); then compound 2.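

In this assay, methyl in place of hydrogen on a saturated chain carbon bound to an oxygen on an aromatic ring gives a 1.8-fold lower number from compound 1 to compound 4 (0.27 log units; within the scatter), so 3-methoxyphenyl and 3-ethoxyphenyl cannot be told apart here. For the compounds shown here, this is the first reading at this place, and it shows that the two places do not answer alike to enlargement: the ethyl and phenyl enlargements on a saturated chain carbon bound to an oxygen next to a carbonyl group each gave a large step beyond the scatter, while this methyl enlargement stays within it. Nothing among the measurements shown accounts for this contrast.

On these data alone, a single step cannot show how far this place accepts enlargement, so it remains open whether a longer chain such as propoxy or butoxy, or a hydroxyl or an amine in place of the ethoxy, would also stay within the scatter of compound 1. As far as these compounds go, it also remains open whether 3-ethoxyphenyl would give a similarly small step when paired with the larger carbonyl side chain of compound 2.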